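The source may report more compounds than this note shows. Statements on the series, on what has been measured and on what is new or still open speak of the compounds shown alone.

Compound 1 `CC(=O)N1CCc2nc(C#Cc3ccccc3)sc2C1` gives 90 nM in an assay on HEK293 cells for negative allosteric modulation of metabotropic glutamate receptor 5 (Homo sapiens), read by FLIPR, with a stated time of 1 h; a higher number here means a weaker inhibitor, a lower number a stronger inhibitor.
Compound 2 `O=C(C1CCCC1)N1CCc2nc(C#Cc3ccccc3)sc2C1` reaches only the limit of this assay, > 10000 nM.
Compound 3 `O=C(C1CCOCC1)N1CCc2nc(C#Cc3ccccc3)sc2C1` likewise reaches only the limit, > 10000 nM.

Compound 3 therefore stands at the limit (the limit of > 10000 nM in this assay, at which 2 of the 3 values shown sit), without a number of its own. Compound 4 `O=C(C1CCCCO1)N1CCc2nc(C#Cc3ccccc3)sc2C1` differs from it in one place: oxan-2-yl in place of oxan-4-yl on a carbonyl carbon. Among the compounds with values here, no measured step carries the same change; the step from compound 2 to compound 3 is unreadable, a step that the two limits leave unreadable from compound 2 to compound 3. The steps that do bear on it are an at least 110-fold higher number from compound 1 to compound 2 (2.04 log units; beyond the scatter) and an at least 110-fold higher number from compound 1 to compound 3 (2.04 log units; beyond the scatter), both large and both ending at the limit. Since the rearranged ring keeps the same count of atoms and acceptors, compound 4 is expected to remain near that limit, with a number no higher from compound 3 to compound 4 (the limit leaves the size open) estimated as no readable change. Compound 4 is thus estimated at 10000 nM, within 2000 nM to 50000 nM.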

Compound 4, half-maximal inhibitory concentration: > 10000 nM
Compound 4: only a limit was reported; the forecaster's own chance of this, stated with the estimate: 75%; the middle value sits exactly at the limit.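

Oxan-2-yl on the carbonyl carbon gives an at least 110-fold higher number from compound 1 to compound 4 (2.04 log units; beyond the scatter) and so behaves no differently from oxan-4-yl in leaving a readable value out of reach. Moving the attachment point within this ring therefore does not recover a measurable value, and the steps among compound 2, compound 3 and compound 4 cannot be read. Three groups at this place now end at one limit: the limit of > 10000 nM in this assay, at which 3 of the 4 values shown sit.

From the compounds shown here alone, whether ethyl or cyclopropyl on the carbonyl carbon keeps a readable value stays open. So does the effect of an amine there.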